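Replacing the Aryl Group While Keeping the Hydroxy

A few compounds are considered here, and "the series" means these few. Any claim that something is new, unique, unknown or untested is made for them only; others in the source may bear on it.

In a functional assay on DWD cells (Homo sapiens) for inhibition, read by sulforhodamine B assay (a lower number here means a stronger inhibitor of growth, a higher number a weaker inhibitor of growth), compound 3 `Oc1cccc2[nH]c(-c3ccc(-c4ccc(-c5ccc(C(F)(F)F)cc5)cc4)cc3)nc12` gives 3180 nM and stands second highest of the three measured numbers. Compound 1 `COc1ccc(-c2ccc(-c3ccc(-c4nc5cc(C)ccc5[nH]4)cc3)cc2)cc1OC` gives 1720 nM within the scatter of that value, and compound 2 `FC(F)(F)c1ccc(-c2ccc(-c3ccc(-c4nc5ccccc5[nH]4)cc3)cc2)cc1` gives 100000 nM on the high side. Compound 4 `COc1ccc(-c2ccc(-c3ccc(-c4nc5c(O)cccc5[nH]4)cc3)cc2)cc1OC` has 3,4-dimethoxyphenyl in place of 4-(trifluoromethyl)phenyl on an aromatic carbon and keeps the hydroxy. Within the data shown here, no measured step covers this exchange. Among the measured compounds shown here, the one measured step, a 31-fold lower number from compound 2 to compound 3 (1.50 log units; beyond the scatter) for hydroxy in place of hydrogen, is large but concerns another place. Compound 1 carries the entering group without the hydroxy, so a modest move to a lower number is expected in this assay rather than a large one. The estimated change is a 2.0-fold lower number from compound 3 to compound 4 (0.30 log units; within the scatter) and sits near the edge of the scatter. For compound 4 the expected value is 1600 nM with an estimated range of 350 nM to 6000 nM overall.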

Compound 4, concentration for 50% growth inhibition: 1400 nM
Compound 4: middle estimate off by 1.1-fold (0.06 log units), on the high side, and the stated range covers the measured number.
By their numbers in this assay, from the lowest: compounds 4, 1 and 3 (each within the scatter of the next, the first and the last beyond it); then compound 2.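

With the hydroxy held fixed, 3,4-dimethoxyphenyl in place of 4-(trifluoromethyl)phenyl gives a 2.3-fold lower number from compound 3 to compound 4 (0.36 log units; beyond the scatter) in this assay, so the aryl group at this position does shift the number, though modestly. With 3,4-dimethoxyphenyl held fixed, 4-hydroxy-1H-benzimidazol-2-yl in place of 5-methyl-1H-benzimidazol-2-yl gives a 1.2-fold lower number from compound 1 to compound 4 (0.09 log units; within the scatter), so this exchange leaves the two compounds indistinguishable here. Nothing available accounts for either step. From the compounds shown here alone, whether an amine or a carboxylic acid in place of the methoxy groups would keep this level remains open.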